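The source may report more compounds than this note shows. Statements on the series, on what has been measured and on what is new or still open speak of the compounds shown alone.

Among the compounds with values here, in a functional assay on HCT-116 cells (Homo sapiens) for antiproliferative activity, read by MTT assay, with a stated time of 72 h (a higher number here means a weaker inhibitor, a lower number a stronger inhibitor), two compounds have values so far. Compound 1 (`CC(=O)c1ccc(-c2cccc(NC(=O)CCc3ccc4c(c3)COB4O)c2)cc1`) gives 63000 nM and compound 2 (`COc1cccc(-c2cccc(NC(=O)CCc3cccc4c3C(O)OC4)c2)c1`) gives 49000 nM. These two values lie within the scatter of each other, so compound 2 stands level with compound 1 on the numbers available.

Compound 3 (`CC(=O)c1ccc(-c2cccc(NC(=O)CCc3cccc4c3C(O)OC4)c2)cc1`) keeps the core of compound 2 and alters one group: 4-acetylphenyl in place of 3-methoxyphenyl on an aromatic carbon. This places 4-acetylphenyl in place of 3-methoxyphenyl on an aromatic carbon, meta to a large group. Within the data shown here, no measured pair of compounds differs in one place, so this assay offers no direct measure of this change. Among the measured compounds shown here, the only indirect guide is compound 1, which carries 4-acetylphenyl on a different core and gives 63000 nM, within the scatter of the value for compound 2. On that basis, no shift beyond the scatter is expected. An estimated step of a 1.0-fold higher number from compound 2 to compound 3 (0.01 log units; within the scatter) is expected. For compound 3 the estimated value is 50000 nM, with an expected range from 25000 nM to 100000 nM.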

Compound 3, half-maximal inhibitory concentration: 18000 nM
Estimate against measurement, compound 3: 2.8-fold (0.44 log units) above; the whole stated range lies above it.
By their numbers in this assay, from the lowest: compound 3; then compounds 2 and 1 (each within the scatter of the next).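

In this assay, 4-acetylphenyl in place of 3-methoxyphenyl on this aromatic carbon, meta to a large group, gives a 2.7-fold lower number from compound 2 to compound 3 (0.43 log units; beyond the scatter) and so shows that the number responds to the group at this place, even though both groups hold one six-membered aromatic ring of carbon only and one hydrogen-bond acceptor. With 4-acetylphenyl held fixed, the change of core gives a 3.5-fold lower number from compound 1 to compound 3 (0.54 log units; beyond the scatter) and so shows that the core also matters, which compounds 1 and 2 could not show, as they differ in more than one place. Nothing measured here gives a reason for either step.

From the compounds shown here alone, it remains open whether the lower number follows the acetyl group itself or its place on the phenyl ring, and what a 3-acetylphenyl or a 4-methoxyphenyl group would give at this position. Also open, going by these compounds, is whether a 4-carboxyphenyl or a 4-aminophenyl group here, or a longer chain to the amide carbonyl, would move the number further in either direction.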